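Piperazine benzimidazoles: swapping the benzyl substituent

The source may hold more compounds than are shown below. What is called first, only, known or untested is meant among the compounds shown, and "the series" means these compounds.

Two members of the series have been run in an assay on isolated protein for inhibition of aldehyde dehydrogenase 1A1 (Homo sapiens), read by spectrophotometry, tested at 10 uM (a higher number here means more inhibition at the concentration tested (going by the name of the read-out), a lower number less inhibition), so far. Compound 1 `CC(=O)N1CCN(Cc2nc3ccccc3n2Cc2cccc(C)c2)CC1` gives 70.3% in this assay. Compound 2 `O=C(C1CC1)N1CCN(Cc2nc3ccccc3n2Cc2ccc(F)cc2)CC1` gives 32.7% in this assay, the lower of the two numbers, and the gap to compound 1 is beyond the usual scatter. Among the measured compounds shown here, compound 1 and compound 2 differ in two places, so no single step between measured compounds is available.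

Compound 3 `Cc1ccccc1Cn1c(CN2CCN(C(=O)C3CC3)CC2)nc2ccccc21` is the next compound to be measured. It differs from compound 2 in one place: 2-methylphenyl in place of 4-fluorophenyl on a saturated chain carbon bound to an aromatic nitrogen. The amide portion of compound 2 is kept.

For the measured compounds named here, with no measured step of this kind, the expectation rests only on compound 2 and compound 1. An increase in inhibition is expected from compound 2 to compound 3, of about a number 14.3 percentage points higher from compound 2 to compound 3 (beyond the scatter), with a wide uncertainty. Compound 3 is therefore estimated to give 47% in this assay, with a range from 22% to 72%.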

Compound 3, a percentage reported as inhibition, at one concentration (the size of the read-out at that concentration, not a potency): 29.1%
The estimate for compound 3 lay 17.9 percentage points above the measured number; low and high end bracket the measured number.
By their numbers in this assay, from the lowest: compounds 3 and 2 (each within the scatter of the next); then compound 1.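

In this assay, among the compounds shown here, 2-methylphenyl in place of 4-fluorophenyl on a saturated chain carbon bound to an aromatic nitrogen gives a number 3.6 percentage points lower from compound 2 to compound 3 (within the scatter), the first single-place step, with the amide portion held constant. With this amide, the position therefore accepts either group without a separation between compound 2 and compound 3, and the exchange of fluorine for a methyl group on the ring, at a different ring position, does not open up a difference. No measurement available here explains this result.

Compound 1 still differs from compound 2 and from compound 3 in two places, so its higher value cannot be assigned to the benzyl group or to the amide alone. Also open, from the compounds shown here alone, is how this position responds to an aminomethyl or carboxylic acid group on the phenyl ring, or to a longer chain in place of the benzyl link.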